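Swapping Chloro for Fluoro on the More Active Compound

The source may report more compounds than this note shows. Statements on the series, on what has been measured and on what is new or still open speak of the compounds shown alone.

Among the compounds with values here, in a functional assay on cells (Tumor Cell line, Homo sapiens) for antiproliferative activity (a lower number here means a stronger inhibitor of growth, a higher number a weaker inhibitor of growth), compound 2 (`Cc1cnc2[nH]c(-c3cccc(Cl)c3)cc(=O)c2c1`) gives 269 nM, the lower of the two numbers so far. Compound 1 (`Oc1cc(-c2ccc3ccccc3c2)nc2ncccc12`) gives 8130 nM, a gap well beyond the scatter. Compound 3 (`Cc1cnc2[nH]c(-c3cccc(F)c3)cc(=O)c2c1`) differs from compound 2 in one place: fluoro in place of chloro on an aromatic carbon. Within the data shown here, no measured pair shows this swap, so the expectation is rough: in this assay, no step beyond the scatter, perhaps a slight weakening. The expected change is a 1.3-fold higher number from compound 2 to compound 3 (0.11 log units; within the scatter). For compound 3 the estimated value is 350 nM, with an expected range of 100 nM to 1200 nM.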

Compound 3, concentration for 50% growth inhibition: 50.1 nM
Compound 3: the middle estimate sits 7.0-fold (0.84 log units) above what was measured; measured number outside the range, below it.
By their numbers in this assay, from the lowest: compound 3; then compound 2; then compound 1.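

This position on the aromatic carbon, meta to a large group, is sensitive to a one-atom change: in this assay, replacing chloro with fluoro gives a 5.4-fold lower number from compound 2 to compound 3 (0.73 log units; beyond the scatter) and lies beyond the scatter. Within the data shown here, compounds 1 and 2 differ in more than one place, so this is the first effect here that can be traced to a single group. No supporting measurement bears on why this swap moves the number. Going by these compounds, whether a methoxy group or an amine at this carbon would lower the number further remains open. So does whether fluoro would have the same effect at another carbon of that ring.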